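Swapping a Benzyl Substituent in a Receptor Binding Series

A few compounds are considered here, and "the series" means these few. Any claim that something is new, unique, unknown or untested is made for them only; others in the source may bear on it.

Among the measured compounds shown here, compound 2 `COc1cccc(OC)c1OCCNCCOc1ccccc1OCc1ccc(C)cc1` stands at the lowest of the two numbers measured so far in an assay on CHO cells for displacement of a labelled ligand from Alpha-1B adrenergic receptor (Homo sapiens); on this read-out lower numbers stand for stronger inhibition and higher numbers for weaker inhibition: compound 2 gives 0.251 nM, whereas compound 1 `COc1cccc(OC)c1OCCNCCOc1ccccc1OCc1ccccc1` gives 0.537 nM. For the measured compounds named here, the only measured step is a 2.1-fold lower number from compound 1 to compound 2 (0.33 log units; beyond the scatter), which comes from methyl in place of hydrogen on an aromatic carbon.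

Compound 3 `COc1cccc(COc2ccccc2OCCNCCOc2c(OC)cccc2OC)c1` has not yet been measured. It differs from compound 2 by 3-methoxyphenyl in place of 4-methylphenyl on a saturated chain carbon bound to an oxygen on an aromatic ring. Going by the values given here, no measured step covers a methoxy group at this place, and the methyl of compound 2 leaves at the same time, so the one known step, a 2.1-fold lower number from compound 1 to compound 2 (0.33 log units; beyond the scatter), bears on it only loosely: it shows that exchanging a small substituent here shifted the number modestly, not dramatically. The expectation is therefore a step of at most modest size, most likely toward a slightly higher number, as expressed by a 1.6-fold higher number from compound 2 to compound 3 (0.20 log units; within the scatter). Compound 3 is estimated at 0.4 nM, with a range from 0.15 nM to 1.1 nM.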

Compound 3, inhibition constant: 2 nM
The estimate for compound 3 lay 5.0-fold (0.70 log units) below the measured number; measured number above the stated range.
By their numbers in this assay, from the lowest: compound 2; then compound 1; then compound 3.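

A substituent on this phenyl group can move the number in either direction in this assay and not only downward: the methoxy of compound 3 gives a 3.7-fold higher number from compound 1 to compound 3 (0.57 log units; beyond the scatter) whereas the methyl of compound 2 gave a 2.1-fold lower number from compound 1 to compound 2 (0.33 log units; beyond the scatter) in the opposite direction. Exchanging 4-methylphenyl for 3-methoxyphenyl on a saturated chain carbon bound to an oxygen on an aromatic ring therefore gives an 8.0-fold higher number from compound 2 to compound 3 (0.90 log units; beyond the scatter) and this is a larger step than either of the other two, with compound 1, which carries neither substituent, lying between compound 2 and compound 3. Nothing available here accounts for this change of direction. The compounds shown change the kind of group and its place on the ring together, so they leave open whether the higher number of compound 3 goes with the methoxy group itself or with where it sits. From the compounds shown here alone, how a chloro or hydroxyl group on this ring would shift the number is also open.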